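A few compounds are considered here, and "the series" means these few. Any claim that something is new, unique, unknown or untested is made for them only; others in the source may bear on it.

Compound 1 `CNC1=C(Cl)C(=O)c2cccnc2C1=O` gives 41100 nM in a functional assay on cells (Neutrophil, Homo sapiens) for inhibition, read by WST assay, with a stated time of 20 min; a lower number here means a stronger inhibitor, a higher number a weaker inhibitor.
Compound 2 `NC1=C(Cl)C(=O)c2ncccc2C1=O` gives only a limit of the assay, > 200000 nM.
Compound 3 `CSC1=C(N)C(=O)c2cccnc2C1=O` gives only a limit of the assay, > 150000 nM.

Compound 1 is thus the only one of the three with a number in this assay; the difference between its core and that of compound 2 is not broken down here. Compound 2 and compound 3 differ by methylsulfanyl in place of chloro on a double-bonded ring carbon, and that step, a step that the two limits leave unreadable from compound 2 to compound 3, cannot be read because the limit of > 200000 nM in this assay, at which 1 of the 3 values shown sits, and the limit of > 150000 nM in this assay, at which 1 of the 3 values shown sits, bound both values. Compound 4 `CNC1=C(SC)C(=O)c2cccnc2C1=O` is not yet measured; it differs from compound 1 by methylsulfanyl in place of chloro on a double-bonded ring carbon, the same kind of change, except that here the neighbouring ring atom bears a methylamino group rather than an amino group. With the earlier step unreadable, the expectation for compound 4 rests only on compound 1 at 41100 nM, and a step of a 1.9-fold higher number from compound 1 to compound 4 (0.29 log units; within the scatter) is expected. Compound 4 is therefore estimated at 80000 nM, between 20000 nM and 300000 nM.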

Compound 4, half-maximal inhibitory concentration: > 200000 nM
Compound 4 ended at the assay's limit; the forecaster's own chance of this, stated with the estimate: 40%; at least 2.5-fold (0.39 log units) between middle value and limit.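

In this assay, methylsulfanyl in place of chloro on the core of compound 1 gives an at least 4.8-fold higher number from compound 1 to compound 4 (0.68 log units; beyond the scatter), a loss that lies beyond the scatter. Compound 4 gives only a limit of the assay: the limit of > 200000 nM in this assay, at which 2 of the 4 values shown sit.

The same change from compound 2 to compound 3 cannot be read, since both give only limits, so the data do not show whether the change has the same effect on both cores.

The compounds shown leave open how bromo or methoxy in place of chloro would read in this assay. They also leave open whether a longer chain, such as ethylamino in place of methylamino, would alter the value of compound 1.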